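Halogen for Methoxy on the Triazole Aryl Arm

The source may hold more compounds than are shown below. What is called first, only, known or untested is meant among the compounds shown, and "the series" means these compounds.

Measured compounds in this set:
compound 1, `COc1cc(-n2ncnc2-c2ccc(F)cc2)cc(OC)c1OC`, with > 10000 nM
compound 2, `COc1cc(-n2ncnc2-c2cccc(F)c2)cc(OC)c1OC`, with > 10000 nM
compound 3, `COc1ccc(-c2ncnn2-c2cc(OC)c(OC)c(OC)c2)cc1`, with 120 nM

Among the compounds with values here, in a functional assay on HL-60 cells (Homo sapiens) for antiproliferative activity, read by MTT assay, with a stated time of 72 h (a lower number here means a stronger inhibitor, a higher number a weaker inhibitor), compound 3 is the only compound that gives a number, 120 nM. For compound 1 the value is a limit of the assay, > 10000 nM. For compound 2 the value is also a limit, > 10000 nM. Two of the three values therefore sit at the limit of > 10000 nM in this assay, at which 2 of the 3 values shown sit, and compound 3 stands alone as the single readable point.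

The unmeasured compound 4, `COc1cc(-n2ncnc2-c2cccc(Cl)c2)cc(OC)c1OC`, differs from compound 3 in one place: 3-chlorophenyl in place of 4-methoxyphenyl on an aromatic carbon.

Within the data shown here, two measured steps bear on this change, and both run toward compound 3 from a fluorophenyl arm: an at least 83-fold lower number from compound 1 to compound 3 (1.92 log units; beyond the scatter), and an at least 83-fold lower number from compound 2 to compound 3 (1.92 log units; beyond the scatter). The step from compound 1 to compound 2 cannot be read, because the limit of > 10000 nM in this assay, at which 2 of the 3 values shown sit, holds both ends. Compound 4 carries a halogen on that arm again, now chlorine in the 3-position, so the step is expected to run back the other way and to be large, with a real chance that compound 4 reports only a limit. The expected step is a 67-fold higher number from compound 3 to compound 4 (1.82 log units; beyond the scatter). For compound 4 the estimate in this assay is 8000 nM, within a range from 1500 nM to 25000 nM.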

Compound 4, half-maximal inhibitory concentration: > 10000 nM
Compound 4: a limit, no number (the forecaster's own chance of this, stated with the estimate: 60%); middle value at least 1.2-fold (0.09 log units) from the limit.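

In this assay, the change from 4-methoxyphenyl to 3-chlorophenyl gives an at least 83-fold higher number from compound 3 to compound 4 (1.92 log units; beyond the scatter). The earlier compounds showed this kind of loss only with a fluorophenyl arm, whereas this step shows it with chlorine on the aromatic carbon between two ring nitrogen atoms, so among the four compounds shown only the 4-methoxyphenyl arm of compound 3 gives a readable number. The steps from compound 1 and from compound 2 to compound 4 cannot be read, and chloro and fluoro cannot be ranked against each other here, because both ends of each step stand at the same limit: the limit of > 10000 nM in this assay, at which 3 of the 4 values shown sit.

The compounds shown leave open whether the readable potency follows the methoxy group itself or its placing on the arm, since the 3-methoxyphenyl and 4-chlorophenyl arms are not among them. They also leave open how other groups on this arm would compare with 4-methoxyphenyl, such as an ethoxy group, a hydroxyl group or a dimethylamino group.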